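Side-chain substituent change at compound 1's saturated-carbon oxygen

A few compounds are considered here, and "the series" means these few. Any claim that something is new, unique, unknown or untested is made for them only; others in the source may bear on it.

Compound 1 `CC(C)=CC[C@@H](OC(=O)CCO)C1=CC(=O)c2c(O)ccc(O)c2C1=O` stands highest of the three numbers measured in a functional assay on DU-145 cells (Homo sapiens) for cytotoxicity, read by MTT assay; a higher number here means a weaker inhibitor, a lower number a stronger inhibitor: compound 1 gives 55300 nM. Compound 2 `CC(C)=CC[C@@H](OC[C@H](C)O)C1=CC(=O)c2c(O)ccc(O)c2C1=O` gives 24500 nM in this assay, and compound 3 `COC(C)CO[C@H](CC=C(C)C)C1=CC(=O)c2c(O)ccc(O)c2C1=O` gives 16600 nM. Compound 4 `CC(C)=CC[C@@H](OCC(C)O)C1=CC(=O)c2c(O)ccc(O)c2C1=O` has not been measured. It differs from compound 1 in one place: 2-hydroxypropyl in place of (2-hydroxyethyl)carbonyl on an oxygen on a saturated carbon.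

The step that bears most directly on this is a 2.3-fold lower number from compound 1 to compound 2 (0.35 log units; beyond the scatter), which carries the same change of group at the same place. The related step of a 3.3-fold lower number from compound 1 to compound 3 (0.52 log units; beyond the scatter) points the same way and is somewhat larger, while a 1.5-fold lower number from compound 2 to compound 3 (0.17 log units; within the scatter) lies within the scatter, so the two ether-type side chains behave alike as far as these numbers show. For compound 4 a modest move toward a lower number in this assay is therefore expected, close to what compound 1 to compound 2 showed, namely a 2.2-fold lower number from compound 1 to compound 4 (0.34 log units; beyond the scatter). The estimate for compound 4 in this assay is 25000 nM, with a range from 12000 nM to 50000 nM.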

Compound 4, half-maximal inhibitory concentration: 16100 nM
Beside the measured number, compound 4's estimate is 1.6-fold (0.19 log units) above it; the range from low to high includes it.
By their numbers in this assay, from the lowest: compounds 4, 3 and 2 (each within the scatter of the next); then compound 1.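

In this assay, 2-hydroxypropyl in place of (2-hydroxyethyl)carbonyl now reads on a second pair, a 3.4-fold lower number from compound 1 to compound 4 (0.54 log units; beyond the scatter), so compounds 2 and 4 both stand apart from compound 1 by more than the scatter. Hydrogen in place of methyl on an oxygen on a saturated carbon gives no readable change, with a 1.0-fold lower number from compound 3 to compound 4 (0.01 log units; within the scatter), so the hydroxy and methoxy forms of this side chain cannot be told apart here. Compound 2 and compound 4 also cannot be told apart, with a 1.5-fold lower number from compound 2 to compound 4 (0.18 log units; within the scatter), and the only difference in that pair is: the fact that one of compounds 2 and 4 is drawn with a defined configuration and the other without, at the place where they differ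

The compounds shown leave open how the opposite drawn configuration at that side-chain carbon would read. They also leave open whether an amine, a carboxylic acid or a longer chain at this oxygen would follow the ether-linked compounds or compound 1.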